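A methoxycarbonyl group added to compound 1

The source may report more compounds than this note shows. Statements on the series, on what has been measured and on what is new or still open speak of the compounds shown alone.

Measured so far in a functional assay with Rattus norvegicus as the target; on this read-out higher numbers stand for weaker inhibition and lower numbers for stronger inhibition:
Compound 1 `COc1cccc2[nH]c(=O)c(=O)oc12`: 7000 nM
Compound 2 `O=c1[nH]c2ccc(O)cc2oc1=O`: 170000 nM

Compound 1 holds the lower of the two numbers and so inhibits more strongly than compound 2, a gap beyond the usual scatter. Compound 3 `COC(=O)c1cc(OC)c2oc(=O)c(=O)[nH]c2c1` has not yet been measured. It differs from compound 1 by methoxycarbonyl in place of hydrogen on an aromatic carbon, with methoxycarbonyl in place of hydrogen on an aromatic carbon, meta to a methoxy group. Among the compounds with values here, no measured pair isolates this change. Resting on compound 1 at 7000 nM, no step beyond the scatter is expected in this assay, in either direction. The estimated step runs a 1.2-fold lower number from compound 1 to compound 3 (0.07 log units; within the scatter). For compound 3 the expected value is 6000 nM, with an estimated range of 1500 nM to 25000 nM.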

Compound 3, half-maximal inhibitory concentration: 3400 nM
Compound 3: the middle estimate sits 1.8-fold (0.25 log units) above what was measured; low and high end bracket the measured number.
By their numbers in this assay, from the lowest: compound 3; then compound 1; then compound 2.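

In this assay, methoxycarbonyl in place of hydrogen on this aromatic carbon, meta to a methoxy group, gives a 2.1-fold lower number from compound 1 to compound 3 (0.31 log units; beyond the scatter), so the position accepts this group and inhibition becomes modestly stronger. Within the data shown here, the earlier compounds held no pair that isolated a change at this carbon, so this is the first reading of a substituent there. Nothing in the data at hand explains the step. The compounds shown leave open how a carboxylic acid or an amine on this same carbon would compare with methoxycarbonyl.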